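Methoxy added on the pyridyl arm of compound 3

The compounds below may be only part of what the source reports. "The series", "measured", "known", "first", "only" and "open" are said of these compounds alone.

The three measured compounds share one core and differ only in the aryl group on the side chain. Compound 2 `C=CC[C@H]1C[C@]2([C@@H](C)Cc3ccccc3)OCOC2=CC1=O` carries a plain phenyl; in a functional assay on NCI-H460 cells (Homo sapiens) for antiproliferative activity, with a stated time of 72 h (a lower number here means a stronger inhibitor, a higher number a weaker inhibitor), compound 2 gives 9700 nM. Compound 1 `C=CC[C@H]1C[C@]2([C@@H](C)Cc3cccc(OC)c3)OCOC2=CC1=O` differs from compound 2 by methoxy in place of hydrogen on an aromatic carbon, and in this assay compound 1 gives 10600 nM; the step is a 1.1-fold higher number from compound 2 to compound 1 (0.04 log units; within the scatter). Compound 3 `C=CC[C@H]1C[C@]2([C@@H](C)Cc3ccc(OC)nc3)OCOC2=CC1=O` differs from compound 2 by 6-methoxypyridin-3-yl in place of phenyl on a saturated chain carbon, two bonds along the chain from a saturated ring carbon; in this assay compound 3 gives 330 nM. The steps of a 29-fold lower number from compound 2 to compound 3 (1.47 log units; beyond the scatter) and a 32-fold lower number from compound 1 to compound 3 (1.51 log units; beyond the scatter) both lie beyond the scatter, so compound 3 stands lowest of the three.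

Compound 4 `C=CC[C@H]1C[C@]2([C@@H](C)Cc3cnc(OC)c(OC)c3)OCOC2=CC1=O` is not yet measured. It differs from compound 3 by methoxy in place of hydrogen on an aromatic carbon. The same kind of change was made from compound 2 to compound 1, but the place differs: in compound 1 the methoxy enters on a six-membered aromatic ring of carbon only, meta to a large group, whereas in compound 4 it enters on a six-membered aromatic ring with 1 nitrogen, ortho to a methoxy group, two atoms from the ring nitrogen and meta to a large group. The two cores differ by 6-methoxypyridin-3-yl in place of phenyl on a saturated chain carbon, two bonds along the chain from a saturated ring carbon.

The number for compound 4 in this assay is expected to stay close to that of compound 3, with an estimated step of a 1.2-fold higher number from compound 3 to compound 4 (0.08 log units; within the scatter); this rests on a 1.1-fold higher number from compound 2 to compound 1 (0.04 log units; within the scatter), which was within the scatter. Among the compounds with values here, only one earlier step of this kind exists, so the range is kept wide. The estimate for compound 4 is 400 nM, expected between 150 nM and 1200 nM.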

Compound 4, half-maximal inhibitory concentration: > 20000 nM
Compound 4: no number, only a limit; the forecaster's own chance of this, stated with the estimate: 2%; middle value at least 50-fold (1.69 log units) from the limit.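

In this assay compound 4 gives > 20000 nM, which is a limit of the assay and not a number. Methoxy in place of hydrogen on an aromatic carbon gives an at least 60-fold higher number from compound 3 to compound 4 (1.78 log units; beyond the scatter), so in this series the near-silent result of the change on the core of compound 2 does not carry over to the core of compound 3: the same change on two cores in this assay, a 1.1-fold higher number (0.04 log units; within the scatter) from compound 2 to compound 1 and an at least 60-fold higher number (1.78 log units; beyond the scatter) from compound 3 to compound 4, at least 55-fold (1.74 log units) apart, beyond the scatter of two such steps This rests on one pair per core and gives the step a lower bound only, so it sets no rule for other cores, does not fix the true size of the step for compound 4, and does not say why the two cores part: the limit of > 20000 nM in this assay, at which 1 of the 4 values shown sits.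

The compounds shown leave open whether the large step belongs to methoxy as such or to any group entering at this place, ortho to a methoxy group and two atoms from the ring nitrogen, and a fluorine atom, a methyl group or a hydroxyl group there would separate these readings. They also leave open whether an ethoxy group in place of the existing methoxy group of compound 3 would be carried by the same core in this assay.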